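Inverting the ring stereocentre of compound 2

The source may hold more compounds than are shown below. What is called first, only, known or untested is meant among the compounds shown, and "the series" means these compounds.

Compound 1, `COc1c(C)cnc(CN2c3nc(N)nc(Cl)c3NC(=O)[C@@H]2C(C)C)c1C`: 1060 nM in a functional assay on HT-29 cells (Homo sapiens) for inhibition; on this read-out higher numbers stand for weaker inhibition and lower numbers for stronger inhibition
Compound 2, `COc1c(C)cnc(CN2c3nc(N)nc(Cl)c3NC(=O)[C@H]2C)c1C`: 470 nM in this assay

Compound 2 gives the lower of the two numbers; the gap to compound 1 lies beyond the scatter. Compound 3, `COc1c(C)cnc(CN2c3nc(N)nc(Cl)c3NC(=O)[C@@H]2C)c1C`, differs from compound 2 only in configuration: the two compounds have the same atoms and bonds and differ only in configuration as drawn: 1 of 1 stereo elements differ; a stereocentre at a saturated ring carbon is drawn R in compound 2 and S in compound 3. For the measured compounds named here, no measured pair in this set separates two such stereoisomers, so the size of the step cannot be read from the data. The expectation is a weaker result, the estimated step of a 5.3-fold higher number from compound 2 to compound 3 (0.73 log units; beyond the scatter) running upward by more than the scatter. Compound 3 is expected at 2500 nM, with a range of 700 nM to 9000 nM.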

Compound 3, half-maximal inhibitory concentration: 660 nM
Beside the measured number, compound 3's estimate is 3.8-fold (0.58 log units) above it; measured number below the stated range.
By their numbers in this assay, from the lowest: compounds 2, 3 and 1 (each within the scatter of the next, the first and the last beyond it).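

In this assay, inverting the ring stereocentre gives a 1.4-fold higher number from compound 2 to compound 3 (0.15 log units; within the scatter), so with methyl on this carbon the read-out does not separate the two configurations. The pair isolates this single change: the fact that compounds 2 and 3 differ only in the configuration as drawn. Methyl in place of isopropyl on the saturated ring carbon gives a 1.6-fold lower number from compound 1 to compound 3 (0.21 log units; within the scatter), so this swap does not separate its two compounds either.

Open, going by these compounds, is whether the configuration matters with isopropyl on this carbon. Also open, on these data alone, is whether a longer chain, a hydroxymethyl or an amine here would shift the number beyond the scatter.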